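The source may hold more compounds than are shown below. What is called first, only, known or untested is meant among the compounds shown, and "the series" means these compounds.

Of the compounds shown here, two have so far been measured in an assay on HEK293 cells for positive allosteric modulation of metabotropic glutamate receptor 3 (Rattus norvegicus), read by thallium flux, with a stated time of 2.5 min; a lower number here means a smaller maximal response, a higher number a larger maximal response. Compound 1, `Cc1c(OCCCCOc2ccccc2C(=O)O)ccc(C(=O)CC2CCCC2)c1C`, gives 28% in this assay. Compound 2, `COc1cc(C(=O)O)ccc1OCCCCOc1ccc(C(=O)CC(C)(C)C)c(O)c1C`, gives 109% in this assay, the higher of the two numbers; compound 1 lies far below it, a gap well beyond the usual scatter. Among the compounds with values here, these two compounds differ in many places at once, so no single structural step can be traced between them, and their gap offers no guide to a small change. Compound 3, `COc1cc(C(=O)O)ccc1OCCCCOc1ccc(C(=O)CC(C)C)c(O)c1C`, has not yet been measured. It differs from compound 2 by a single change: hydrogen in place of methyl on a saturated chain carbon bound to three saturated chain carbons. A change this small is expected to leave the maximal response close to where compound 2 stands. The step of a number 14 percentage points lower from compound 2 to compound 3 (beyond the scatter) is expected to fall within the scatter or to amount at most to a modest drop. The estimate for compound 3 is 95%, with a range from 60% to 120%.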

Compound 3, largest response reached (reported as percent of maximum), in percent of the reference or control that the assay uses: 73.9%
Estimate against measurement, compound 3: 21.1 percentage points above; measured number inside the range.
By their numbers in this assay, from the lowest: compound 1; then compound 3; then compound 2.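

Within the data shown here, the change of tert-butyl to isopropyl gives a number 35.1 percentage points lower from compound 2 to compound 3 (beyond the scatter) in this assay, the first step here that can be read at a single place. It shows that this position is sensitive: hydrogen in place of methyl removes only one carbon, with no ring, hydrogen-bond donor, hydrogen-bond acceptor or charge entering or leaving, yet the step is large. No measurement at hand explains why this single carbon matters so much.

The compounds shown leave open whether trimming this end further, to an ethyl group, would lower the maximal response again, or whether a larger group, such as a cyclohexyl ring, would keep or raise it. They also leave open whether the same change would have a step of similar size on the core of compound 1.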